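The source may hold more compounds than are shown below. What is called first, only, known or untested is meant among the compounds shown, and "the series" means these compounds.

Values in an ADME assay on microsomes from liver (Homo sapiens) for metabolic stability, read by LC-MS, using NADPH, with a stated time of 10 min, tested at 0.5 uM (on this read-out lower numbers stand for a less stable compound and higher numbers for a more stable compound), for the series so far are these:

- compound 1 `CC(=O)Nc1cc(-c2ccc(OC[C@@](C)(N)CC(C)C)c(F)c2)ccn1` gives 91%
- compound 2 `CC(=O)Nc1cc(-c2ccc(OC[C@@H](N)CC(C)C)c(F)c2)ccn1` gives 90%
- compound 3 `COC(=O)Nc1cc(-c2ccc(OC[C@@](C)(N)CC(C)C)cn2)ccn1` gives 93%

All three values lie within the scatter of one another, so compound 1 has no meaningful rank among them. The next compound to read is compound 4 `COC(=O)Nc1cc(-c2ccc(OC[C@@](C)(N)CC(C)C)c(F)c2)ccn1`, which has not been measured. Its difference from compound 1 is methoxy in place of methyl on a carbonyl carbon and amounts to methoxy in place of methyl on a carbonyl carbon, or acetamido to (methoxycarbonyl)amino when cut one bond further out.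

Going by the values given here, the only measured step is a number 1 percentage points lower from compound 1 to compound 2 (within the scatter). That step is small, but it lies on a saturated chain carbon and does not test the carbonyl change. Among the compounds with values here, no measured pair isolates this change. Compound 3 already carries the (methoxycarbonyl)amino group, but it differs from compound 1 in other ways too. Compound 3 at 93% nevertheless lies within the scatter of compound 1 at 91%. On that limited evidence, no shift beyond the scatter is expected in this assay, and the estimated step is no change at the digits printed from compound 1 to compound 4 (within the scatter). For compound 4 the expected value is 91%, with an estimated range from 82% to 98%.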

Compound 4, percent of the compound remaining: 82%
The estimate for compound 4 lay 9 percentage points above the measured number; the range from low to high includes it.
By their numbers in this assay, from the lowest: compounds 4, 2, 1 and 3 (each within the scatter of the next, the first and the last beyond it).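

In this assay, going by these compounds alone, the first reading at the carbonyl carbon bound to the amide-type nitrogen is a number 9 percentage points lower from compound 1 to compound 4 (within the scatter), so replacing methyl with methoxy here, or acetamido with (methoxycarbonyl)amino, gives no shift that can be separated from the scatter. The same (methoxycarbonyl)amino group appears in compound 3 at 93% and in compound 4 at 82%, two values that lie beyond the scatter of each other, so the reading for this group is not the same on both cores. No available evidence bears on the reason for either value.

Within the data shown here, whether the lower value of compound 4 would hold up in repeated measurements remains open, and the single step at this position cannot separate a small real loss from ordinary scatter. Also open, on these data alone, is how this carbonyl carbon would read with an ethyl group, a longer chain or a dimethylamino group in place of methyl or methoxy, on the core of compound 1 and on that of compound 3.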